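Moving the Hydroxyl Group: From Compound 3 to Compound 4

The compounds below may be only part of what the source reports. "The series", "measured", "known", "first", "only" and "open" are said of these compounds alone.

compound 1 `Oc1ccc(-c2cc(-c3ccccc3F)cc(-c3ccccc3O)n2)cc1`: > 50000 nM
compound 2 `Oc1ccc(-c2cc(-c3cccc(F)c3)cc(-c3ccccc3O)n2)cc1`: > 50000 nM
compound 3 `Oc1cccc(-c2cc(-c3cccc(C(F)(F)F)c3)cc(-c3ccccc3O)n2)c1`: 19500 nM

In a functional assay on HeLa cells (Homo sapiens) for inhibition (on this read-out lower numbers stand for stronger inhibition and higher numbers for weaker inhibition), compound 1 gives only a limit, > 50000 nM, not a number. Compound 2 likewise gives a limit, > 50000 nM. Within the data shown here, compound 3 is thus the only compound with a measured number, 19500 nM. Among the measured compounds shown here, the single measured step, a step that the two limits leave unreadable from compound 1 to compound 2, offers no readable size. Compound 4 `Oc1ccc(-c2cc(-c3cccc(C(F)(F)F)c3)cc(-c3ccccc3O)n2)cc1` differs from compound 3 by 4-hydroxyphenyl in place of 3-hydroxyphenyl on an aromatic carbon. For the measured compounds named here, no measured step covers this change directly. What exists is the limit of > 50000 nM in this assay, at which 2 of the 3 values shown sit, and both compounds sitting at that limit carry the 4-hydroxyphenyl group that enters here, while compound 3 carries 3-hydroxyphenyl. Compound 4 is therefore expected to be somewhat weaker, a step of a 1.8-fold higher number from compound 3 to compound 4 (0.25 log units; within the scatter). Compound 4 is estimated at 35000 nM, between 12000 nM and 100000 nM.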

Compound 4, half-maximal inhibitory concentration: > 50000 nM
Compound 4 was reported as a limit; the forecaster's own chance of this, stated with the estimate: 45%; at least 1.4-fold (0.15 log units) between middle value and limit.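

In this assay, putting 4-hydroxyphenyl in place of 3-hydroxyphenyl on the aromatic carbon next to the ring nitrogen gives an at least 2.5-fold higher number from compound 3 to compound 4 (0.40 log units; beyond the scatter). Among these compounds, the two groups have the same atoms, so here the place of the hydroxyl alone separates the pair, a comparison the earlier compounds could not offer. The steps from compound 1 and compound 2 to compound 4 cannot be read, as each joins two limits.

Still open, from the compounds shown here alone, is whether a 3-aminophenyl group at this carbon would match 3-hydroxyphenyl. Going by these compounds, it is also open whether 3-hydroxyphenyl keeps its edge with fluoro in place of trifluoromethyl.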